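The compounds below may be only part of what the source reports. "The series", "measured", "known", "first", "only" and "open" are said of these compounds alone.

Compound 1 `CCOc1ccc(C)c(-c2cccc(COc3ccc(OCC(=O)O)c(F)c3)c2)c1` carries an ethoxy group on the aryl ring that bears the methyl group, and in a functional assay on CHO cells for agonist activity at Free fatty acid receptor 1 (Homo sapiens), read by FLIPR and calcium flux (a higher number here means that more compound is needed for the effect, a lower number that less compound is needed), compound 1 gives 220 nM, the lowest number among the three compounds measured here. Compound 2 `CCCOc1ccc(C)c(-c2cccc(COc3ccc(OCC(=O)O)c(F)c3)c2)c1` lengthens that chain to propoxy, and in this assay compound 2 gives 610 nM. Compound 3 `Cc1ccc(OCC(C)C)cc1-c1cccc(COc2ccc(OCC(=O)O)c(F)c2)c1` carries an isobutoxy group instead, and in this assay compound 3 gives 1450 nM.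

Compound 4 `Cc1ccc(OCC2CC2)cc1-c1cccc(COc2ccc(OCC(=O)O)c(F)c2)c1` differs from compound 1 by cyclopropyl in place of methyl on a saturated chain carbon bound to an oxygen on an aromatic ring. Within the data shown here, two measured steps bear on this change. The closest is the change at the same place, where a 6.6-fold higher number from compound 1 to compound 3 (0.82 log units; beyond the scatter). Adding a single carbon further along the chain gave a 2.8-fold higher number from compound 1 to compound 2 (0.44 log units; beyond the scatter). The change to compound 4 adds more carbon than the step to compound 2 but, as a three-membered ring, is a different branching than the step to compound 3. On this basis, compound 4 is expected to need more compound than compound 1, with a 3.2-fold higher number from compound 1 to compound 4 (0.50 log units; beyond the scatter) as the expected step, beyond the scatter. In this assay compound 4 is estimated at 700 nM, with a range from 300 nM to 1800 nM.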

Compound 4, half-maximal effective concentration: 340 nM
Beside the measured number, compound 4's estimate is 2.1-fold (0.31 log units) above it; the measured number falls inside the stated range.
By their numbers in this assay, from the lowest: compounds 1, 4 and 2 (each within the scatter of the next, the first and the last beyond it); then compound 3.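

Among these compounds, replacing methyl with cyclopropyl on the saturated chain carbon bound to an oxygen on an aromatic ring gives a 1.5-fold higher number from compound 1 to compound 4 (0.19 log units; within the scatter) in this assay, and the comparison with the ethyl of the propoxy chain gives a 1.8-fold lower number from compound 2 to compound 4 (0.25 log units; within the scatter), so compound 4 cannot be ordered against either compound 1 or compound 2, and it is the first group at this place that adds carbon to the ethoxy chain of compound 1 without a step beyond the scatter. Among the compounds shown here, the comparison with the isopropyl of the isobutoxy chain gives a 4.3-fold lower number from compound 3 to compound 4 (0.63 log units; beyond the scatter) and is the only new step beyond the scatter, which shows that a closed three-membered ring and an open branch on the same carbon do not read alike here, and that compound 4 goes against the rise in the number seen along compounds 1, 2 and 3. Nothing given here offers a reason for this difference between the ring and the branch.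

On these data alone, whether the result belongs to the three-membered ring alone remains open, since a cyclobutyl or cyclopentyl group at the same place would be needed to say so. As far as these compounds go, it is equally open how a chain carrying an ether oxygen, such as methoxyethoxy in place of ethoxy, or a trifluoromethyl group at the end of the chain, would read on the same core.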